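Swapping hydroxy for fluoro and cytotoxicity in dog cells

The source may hold more compounds than are shown below. What is called first, only, known or untested is meant among the compounds shown, and "the series" means these compounds.

Compound 1, `COc1cccc([C@H]2CC(C)(O)[C@@H]3CC[C@@H](C)C[C@H]3O2)c1OC`, gives > 937000 nM.
Compound 2, `COc1ccc(OC)c([C@H]2CC(C)(O)[C@@H]3CC[C@@H](C)C[C@H]3O2)c1`, gives 512000 nM.
Compound 3, `COc1cccc([C@H]2CC(C)(F)[C@@H]3CC[C@@H](C)C[C@H]3O2)c1OC`, gives 180000 nM.

All three were tested in an ADME assay on MDCK cells (Canis lupus familiaris) for cytotoxicity, read by MTT assay, with a stated time of 48 h; on this read-out lower numbers stand for higher toxicity in this test and higher numbers for lower toxicity in this test. For compound 1 the result is a limit of the assay rather than a number, (the limit of > 937000 nM in this assay, at which 1 of the 3 values shown sits). Among the numbers that were obtained, compound 2 stands highest; compound 3 sits a step below it that is beyond the usual scatter.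

Compound 1 and compound 2 are built from the same atoms joined differently; the difference between the two cores is not broken down here. Compound 3 differs from compound 1 by a single change, (fluoro in place of hydroxy on a saturated ring carbon). This change produced an at least 5.2-fold lower number from compound 1 to compound 3 (0.71 log units; beyond the scatter).

Compound 4, `COc1ccc(OC)c([C@H]2CC(C)(F)[C@@H]3CC[C@@H](C)C[C@H]3O2)c1`, has not yet been measured in this assay. It differs from compound 2 by the same change in the same place, (fluoro in place of hydroxy on a saturated ring carbon). Among the compounds with values here, the step from compound 2 to compound 4 is expected to be a 4.3-fold lower number from compound 2 to compound 4 (0.63 log units; beyond the scatter), resting on the single earlier example of this change, an at least 5.2-fold lower number from compound 1 to compound 3 (0.71 log units; beyond the scatter), which is the only evidence available and comes from a different core. Compound 4 is therefore estimated at 120000 nM. The expected range for compound 4 runs from 50000 nM to 300000 nM.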

Compound 4, half-maximal cytotoxic concentration: 37000 nM
Compound 4: middle estimate off by 3.2-fold (0.51 log units), on the high side; measured number below the stated range.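

In this assay, fluoro in place of hydroxy on the saturated ring carbon gave a 14-fold lower number from compound 2 to compound 4 (1.14 log units; beyond the scatter), and a lower number here stands for higher toxicity in this test, so the second core moved in the same direction as the first. Setting the two cores side by side gives the following comparison: the same change on two cores in this assay, an at least 5.2-fold lower number (0.71 log units; beyond the scatter) from compound 1 to compound 3 and a 14-fold lower number (1.14 log units; beyond the scatter) from compound 2 to compound 4; the limit leaves it open whether they differ For compound 1 the result, > 937000 nM, is a limit of the assay and not a number; the direction of the change therefore held on both cores shown, while whether its size carries from one core to the other remains unsettled, and two cores cannot establish a rule for the whole series.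

The compounds shown carry only hydroxy or fluoro on this ring carbon, which leaves open how an amine, a methoxy group or a chlorine atom in that place would read in this assay. They also leave open whether the swap from hydroxy to fluoro would lower the number on a third core, for instance one with a different group in place of the two methoxy groups.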